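This account rests on a few compounds, and the source may have more. Where it says the series, first, only, none or still open, it means among the compounds named here.

Working notes on a set of amides sharing one core, read in an assay for inhibition of apolipoprotein B-100 (Homo sapiens), tested at 100 nM; on this read-out higher numbers stand for weaker inhibition and lower numbers for stronger inhibition. Compound 1 `COc1cccc(C(=O)Nc2ccc3c(c2)CC(NS(=O)(=O)c2ccccc2)C3)c1-c1ccc(Cl)cc1` gives 2 nM in this assay. Compound 2 `Cc1cccc(C(=O)Nc2ccc3c(c2)C[C@H](NS(C)(=O)=O)C3)c1-c1ccc(C(F)(F)F)cc1` gives 1.8 nM in this assay. Compound 3 `CC(=O)NC1Cc2ccc(NC(=O)c3ccccc3-c3ccc(C(F)(F)F)cc3)cc2C1` gives 120 nM in this assay, the highest of the three numbers; its distance to compound 1 and its distance to compound 2 both lie well beyond the scatter, so compound 3 is the weakest inhibitor among the measured compounds.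

Compound 4 `CN(C)C(=O)NC1Cc2ccc(NC(=O)c3ccccc3-c3ccc(C(F)(F)F)cc3)cc2C1` is not yet measured. Relative to compound 3 it carries dimethylamino in place of methyl on a carbonyl carbon. Among the compounds with values here, no step between two measured compounds shows this exchange, and no measured pair differs only at that carbonyl. Compounds 1 and 2 carry a sulfonamide instead of an acetamido group and give far lower numbers, but they differ from compound 3 in more than one way, so nothing ties that gap to the exchange at hand. The expectation for compound 4 therefore rests on the acetamido starting point alone. The step from compound 3 to compound 4 in this assay is expected to be small, a 1.5-fold lower number from compound 3 to compound 4 (0.18 log units; within the scatter), tending if anything toward a lower number but not clearly beyond the scatter. Compound 4 is estimated at 80 nM, with a range from 25 nM to 300 nM.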

Compound 4, half-maximal inhibitory concentration: 120 nM
Estimate against measurement, compound 4: 1.5-fold (0.18 log units) below; the range from low to high includes it.
By their numbers in this assay, from the lowest: compounds 2 and 1 (each within the scatter of the next); then compounds 3 and 4 (each within the scatter of the next).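

In this assay, replacing methyl with dimethylamino on a carbonyl carbon whose other neighbour is an amide-type nitrogen, that is, acetamido to (dimethylcarbamoyl)amino, gives no change at the digits printed from compound 3 to compound 4 (within the scatter). Within the data shown here, this is the first step that changes this carbonyl substituent alone, and it shows that, with the rest of compound 3 held fixed, the read-out does not separate the methyl from the larger dimethylamino group. The result covers this one exchange only and sets no general rule for the position, and no measurement at hand explains the flat step.

The compounds shown leave open whether the read-out would also stay flat with a longer chain such as n-butyl, a carboxylic acid or a primary amine on this carbonyl carbon. Among these compounds, they also leave open how much of the gap between compound 3 or compound 4 and the sulfonamides, compound 1 and compound 2, belongs to this position, since no pair here differs at that group alone; a methanesulfonamido group placed on the otherwise unchanged frame of compound 3 would read that directly.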